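The source may hold more compounds than are shown below. What is called first, only, known or untested is meant among the compounds shown, and "the series" means these compounds.

Compound 1 `CCCN1C(=O)CC[C@H]1C(=O)NCc1ccc(F)cc1Cl`: 158 nM
Compound 2 `O=C(NCc1ccc(F)cc1Cl)[C@@H]1CCC(=O)N1Cc1ccccc1`: < 1000 nM
Compound 3 `O=C(NCc1ccc(F)cc1Cl)[C@@H]1CCC(=O)N1C1CCCC1`: not yet measured

In an assay on isolated protein for inhibition of P2X purinoceptor 7 (Homo sapiens) (on this read-out lower numbers stand for stronger inhibition and higher numbers for weaker inhibition), compound 1 gives 158 nM. For compound 2 only a limit is recorded, < 1000 nM, so compound 2 stands at the limit of < 1000 nM in this assay, at which 1 of the 2 values shown sits, rather than at a number. The step that the limit leaves unreadable from compound 1 to compound 2 is therefore of unreadable size. Compound 3 differs from compound 2 by cyclopentyl in place of benzyl on an amide-type nitrogen in a ring. Among the compounds with values here, no measured step of readable size bears on this change, so the expectation rests on compound 1 alone. Compound 3 is expected near 300 nM, between 80 nM and 1200 nM. The step that the limit leaves unreadable from compound 2 to compound 3 is thus estimated, its direction uncertain given the limit for compound 2.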

Compound 3, half-maximal inhibitory concentration: 501 nM
For compound 3 the middle estimate is 1.7-fold (0.22 log units) below the measured one; measured number inside the range.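

In this assay, within the data shown here, the series now shows a 3.2-fold higher number from compound 1 to compound 3 (0.50 log units; beyond the scatter) as propyl gives way to cyclopentyl on the amide-type nitrogen in a ring, the first readable change at this position and a modest one beyond the scatter. Compound 2 carries only a limit, so neither step that involves it can be read: the limit of < 1000 nM in this assay, at which 1 of the 3 values shown sits. Going by these compounds, the comparison of cyclopentyl with benzyl therefore stays open. Also open, on these data alone, is how a longer chain or a chain ending in an amine on this nitrogen would read out.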